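Methoxy for Fluoro Across Two Related Cores

The compounds below may be only part of what the source reports. "The series", "measured", "known", "first", "only" and "open" are said of these compounds alone.

This account concerns four compounds tested, or to be tested, in a functional assay on PC-3 cells (Homo sapiens) for cytotoxicity, read by WST assay, with a stated time of 24 h; on this read-out lower numbers stand for stronger inhibition and higher numbers for weaker inhibition. Compound 1 `COc1ccc2c(/C=C(\C#N)C(=O)c3c[nH]c4cc(F)ccc34)c[nH]c2c1` carries a methoxy group where compound 2 `N#C/C(=C\c1c[nH]c2cc(F)ccc12)C(=O)c1c[nH]c2cc(F)ccc12` carries fluoro. In this assay compound 1 gives > 50000 nM, which is a limit of the assay and not a number. In this assay compound 2 gives > 50000 nM, again a limit rather than a number. The change from compound 2 to compound 1 is methoxy in place of fluoro on an aromatic carbon, and the step that the two limits leave unreadable from compound 2 to compound 1 is unreadable, as the limit of > 50000 nM in this assay, at which 3 of the 3 values shown sit, records.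

Compound 3 `N#C/C(=C\c1cn(Cc2ccc(Cl)cc2)c2ccccc12)C(=O)c1c[nH]c2cc(F)ccc12` differs from compound 2 in its core; the difference between the two cores is not broken down here. In this assay compound 3 gives > 50000 nM, once more a limit of the assay.

Compound 4 `COc1ccc2c(C(=O)/C(C#N)=C/c3cn(Cc4ccc(Cl)cc4)c4ccccc34)c[nH]c2c1` has not yet been measured. It differs from compound 3 by methoxy in place of fluoro on an aromatic carbon, the same change that turns compound 2 into compound 1, at the same place on the ring. That earlier step was unreadable, and no measured size carries over from it. Compound 4 is therefore expected to remain at the limit as well, with an expected step that the limit leaves unreadable from compound 3 to compound 4 that is essentially flat. The estimate for compound 4 in this assay is 70000 nM, with an expected range from 20000 nM to 250000 nM.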

Compound 4, half-maximal inhibitory concentration: > 50000 nM
Compound 4 ended at the assay's limit; the forecaster's own chance of this, stated with the estimate: 85%; the middle value does not contradict the limit.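

No new step can be read from compound 3 to compound 4, because both values are limits of the assay and not numbers: the limit of > 50000 nM in this assay, at which 4 of the 4 values shown sit. What the compounds shown leave open is how methoxy and fluoro compare in this assay on either core, and whether compound 1, compound 2, compound 3 and compound 4 differ at all in this read-out.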